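Adding an Amino Group to an Inactive Nucleoside Core

This account rests on a few compounds, and the source may have more. Where it says the series, first, only, none or still open, it means among the compounds named here.

Compound 1, `O=c1[nH]cnc2c1c(-c1ccsc1)cn2[C@@H]1O[C@H](CO)[C@@H](O)[C@H]1O`: in a functional assay on HCT-116 cells (Homo sapiens), read by MTT assay, with a stated time of 72 h (on this read-out higher numbers stand for weaker inhibition and lower numbers for stronger inhibition), compound 1 gives > 20000 nM, which is a limit of the assay and not a number.
Compound 2, `O=c1[nH]cnc2c1c(-c1ccccc1)cn2[C@@H]1O[C@H](CO)[C@@H](O)[C@H]1O`: in this assay compound 2 gives > 100000 nM, again a limit of the assay.

Compound 1 thus stands only at a limit in this assay; the other value shown is a limit as well. Within the data shown here, the one measured step, a step that the two limits leave unreadable from compound 1 to compound 2, cannot be read because the limit of > 100000 nM in this assay, at which 1 of the 2 values shown sits, and the limit of > 20000 nM in this assay, at which 1 of the 2 values shown sits, are both limits, so it tells nothing about size or direction.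

Compound 3, `Nc1nc2c(c(-c3ccsc3)cn2[C@@H]2O[C@H](CO)[C@@H](O)[C@H]2O)c(=O)[nH]1`, differs from compound 1 by amino in place of hydrogen on an aromatic carbon. Among the measured compounds shown here, no measured step touches this change, so there is no basis to expect a shift in either direction beyond the scatter. Compound 3 is therefore estimated at 50000 nM, with a range of 10000 nM to 200000 nM, most likely reported again as a limit. The step this estimate implies, a step that the limit leaves unreadable from compound 1 to compound 3, is an expectation only.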

Compound 3, half-maximal inhibitory concentration: > 20000 nM
Compound 3: only a limit was reported (the forecaster's own chance of this, stated with the estimate: 80%); the middle value does not contradict the limit.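

In this assay compound 3 gives > 20000 nM, a limit of the assay and not a number. With compound 1 also at a limit, the step from compound 1 to compound 3 cannot be read. The compounds shown leave open whether amino in place of hydrogen changes inhibition at all, and how strongly any of them acts on these cells.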